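Widening the Amine Ring on the Shared Core

The compounds below may be only part of what the source reports. "The series", "measured", "known", "first", "only" and "open" are said of these compounds alone.

compound 1, `O=C(CCc1ccc(C(F)(F)F)cc1)Nc1ccc2nc(N3CCC3)ccc2c1`: 56 nM
compound 2, `O=C(CCc1ccc(C(F)(F)F)cc1)Nc1ccc2nc(N3CC4CC3CN4)ccc2c1`: 490 nM
compound 3, `CC(=O)NC1CCN(c2ccc3cc(NC(=O)CCc4ccc(C(F)(F)F)cc4)ccc3n2)C1`: 440 nM

For the measured compounds named here, in a functional assay on HEK293 cells for activation of melanin-concentrating hormone receptor 1 (Rattus norvegicus), read by inositol phosphate accumulation (a higher number here means that more compound is needed for the effect, a lower number that less compound is needed), compound 1 gives 56 nM, the lowest of the three numbers measured so far. Replacing its small ring with a larger one moved the number up in both known cases: an 8.8-fold higher number from compound 1 to compound 2 (0.94 log units; beyond the scatter), and a 7.9-fold higher number from compound 1 to compound 3 (0.90 log units; beyond the scatter). Between the two larger compounds there is nothing to separate: a 1.1-fold lower number from compound 2 to compound 3 (0.05 log units; within the scatter).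

Compound 4, `O=C(CCc1ccc(C(F)(F)F)cc1)Nc1ccc2nc(N3CCCCC3)ccc2c1`, has not yet been measured. Its change from compound 1 is piperidin-1-yl in place of azetidin-1-yl on an aromatic carbon. Both measured steps from compound 1 bear on this one, since each also enlarged the group at this position, and each gave a modest rise beyond the scatter. The group entering compound 4 is smaller in count than either of those and brings no new hydrogen-bond donor, so the rise is expected to be smaller than in those two steps but still noticeable. Compound 4 is therefore estimated at 150 nM, with a range from 50 nM to 500 nM, which means an expected step of a 2.7-fold higher number from compound 1 to compound 4 (0.43 log units; beyond the scatter).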

Compound 4, half-maximal effective concentration: 110 nM
Compound 4: middle estimate off by 1.4-fold (0.13 log units), on the high side; the range from low to high includes it.
By their numbers in this assay, from the lowest: compounds 1 and 4 (each within the scatter of the next); then compounds 3 and 2 (each within the scatter of the next).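

In this assay, piperidin-1-yl can stand in place of azetidin-1-yl on this aromatic carbon with no change that clears the scatter (a 2.0-fold higher number from compound 1 to compound 4 (0.29 log units; within the scatter)), so a larger plain ring does not by itself raise the number. Compound 4 instead separates from the two compounds with more elaborate groups at this position (a 4.0-fold lower number from compound 3 to compound 4 (0.60 log units; beyond the scatter); a 4.5-fold lower number from compound 2 to compound 4 (0.65 log units; beyond the scatter)), which shows that the rises seen earlier came with something other than a move away from the small azetidine ring, though these compounds cannot tell whether that is the extra nitrogen, the acetamido group, the bridged shape or the overall size. Nothing measured here gives a reason for this difference.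

From the compounds shown here alone, it remains open whether a single added ring nitrogen, as in piperazin-1-yl, or a ring oxygen, as in morpholin-4-yl, would be enough to move the number towards those of compound 2 and compound 3. A plain pyrrolidin-1-yl group would also be informative, since comparing it with compound 3 would isolate the contribution of the acetamido group from that of its ring.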